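Adding a Methoxy Group to the Benzamide of Compound 3

The compounds below may be only part of what the source reports. "The series", "measured", "known", "first", "only" and "open" are said of these compounds alone.

In a functional assay on HL-60 cells (Homo sapiens) for antiproliferative activity, with a stated time of 24 h (on this read-out lower numbers stand for stronger inhibition and higher numbers for weaker inhibition), compound 3 `NC(=O)c1c(NC(=O)c2ccccc2)sc2c1CCN(C(=S)Nc1ccccc1Cl)C2` gives 13800 nM, the lowest of the three numbers measured. Compound 1 `Cc1ccccc1NC(=S)N1CCc2c(sc(NC(=O)c3ccccc3Cl)c2C(N)=O)C1` gives 22600 nM, which lies within the scatter of compound 3, while compound 2 `COc1ccccc1NC(=S)N1CCc2c(sc(NC(=O)c3ccccc3Cl)c2C(N)=O)C1` gives 40900 nM, which lies beyond it. Compound 4 `COc1ccccc1C(=O)Nc1sc2c(c1C(N)=O)CCN(C(=S)Nc1ccccc1Cl)C2` differs from compound 3 by methoxy in place of hydrogen on an aromatic carbon. For the measured compounds named here, the only measured step with a related change is a 1.8-fold higher number from compound 1 to compound 2 (0.26 log units; within the scatter), where a methoxy took the place of a methyl. Going by the values given here, no measured pair shows a methoxy taking the place of hydrogen, so the expectation rests on that single step. For compound 4 a step of a 1.3-fold higher number from compound 3 to compound 4 (0.12 log units; within the scatter) is expected, staying within the scatter. Compound 4 is therefore estimated at 18000 nM, in the range 7000 nM to 45000 nM.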

Compound 4, half-maximal inhibitory concentration: 20800 nM
Beside the measured number, compound 4's estimate is 1.2-fold (0.06 log units) below it; measured number inside the range.
By their numbers in this assay, from the lowest: compounds 3, 4, 1 and 2 (each within the scatter of the next, the first and the last beyond it).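

In this assay the change from phenyl to 2-methoxyphenyl gives a 1.5-fold higher number from compound 3 to compound 4 (0.18 log units; within the scatter), the first measured case of methoxy taking the place of hydrogen, here ortho to a large group. At this position, then, the added methoxy leaves the number within the scatter of the parent compound. No supporting measurement is available to explain this result. Still open, from the compounds shown here alone, is how a different group at this same position, such as an amine or a carboxylic acid, would read out, and whether methoxy would behave alike elsewhere on this ring.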